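Amide cap variation on the bis-indole nitrile core

The source may report more compounds than this note shows. Statements on the series, on what has been measured and on what is new or still open speak of the compounds shown alone.

Measured so far in a functional assay on MCF7 cells (Homo sapiens) for cytotoxicity, read by MTT assay, with a stated time of 72 h; on this read-out lower numbers stand for stronger inhibition and higher numbers for weaker inhibition:
- compound 1, `CN1[C@@H]2c3[nH]c4ccccc4c3C[C@H]1[C@H](C#N)N1[C@@H](CN3C(=O)c4ccccc4C3=O)c3[nH]c4ccccc4c3C[C@@H]21`: 610 nM
- compound 2, `CN1[C@@H]2c3[nH]c4ccccc4c3C[C@H]1[C@H](C#N)N1[C@@H](CNC(=O)c3cccc(C(F)(F)F)c3)c3[nH]c4ccccc4c3C[C@@H]21`: 110 nM
- compound 3, `CN1[C@@H]2c3[nH]c4ccccc4c3C[C@H]1[C@H](C#N)N1[C@@H](CNC(=O)c3ccc(F)cc3)c3[nH]c4ccccc4c3C[C@@H]21`: 980 nM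

Compound 3 has the highest number of the three. Its nearest neighbour is compound 1, a 1.6-fold higher number from compound 1 to compound 3 (0.21 log units; within the scatter); its furthest is compound 2, an 8.9-fold higher number from compound 2 to compound 3 (0.95 log units; beyond the scatter). For the measured compounds named here, only the second of these steps lies beyond the scatter, so the comparison of compound 2 with compound 3 is the one informative step in this assay: a change of the aromatic group on the carbonyl carbon moved the number by a modest amount.

Compound 4, `CN1[C@@H]2c3[nH]c4ccccc4c3C[C@H]1[C@H](C#N)N1[C@@H](CNC(=O)c3ccc4ccccc4n3)c3[nH]c4ccccc4c3C[C@@H]21`, differs from compound 3 in one place: quinolin-2-yl in place of 4-fluorophenyl on a carbonyl carbon. Going by the values given here, no measured pair shows this change, so the expectation rests on the single aryl-swap step from compound 2 to compound 3, which was modest in size, and on the step from compound 1 to compound 3, which stayed within the scatter. A modest move in this assay, toward a lower number, is therefore expected, a 2.5-fold lower number from compound 3 to compound 4 (0.39 log units; beyond the scatter), though a result within the scatter of compound 3 cannot be excluded. For compound 4 the estimate in this assay is 400 nM, with a range of 120 nM to 1500 nM.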

Compound 4, half-maximal inhibitory concentration: 150 nM
The estimate for compound 4 lay 2.7-fold (0.43 log units) above the measured number, and the stated range covers the measured number.
By their numbers in this assay, from the lowest: compounds 2 and 4 (each within the scatter of the next); then compounds 1 and 3 (each within the scatter of the next).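

In this assay the step of a 6.5-fold lower number from compound 3 to compound 4 (0.82 log units; beyond the scatter) shows that a second change of aryl group on this carbonyl carbon, here quinolin-2-yl in place of 4-fluorophenyl, also goes beyond the scatter. With a 1.4-fold higher number from compound 2 to compound 4 (0.13 log units; within the scatter) inside the scatter, quinolin-2-yl and 3-(trifluoromethyl)phenyl cannot be told apart at this place, and of the three aryl amides only the 4-fluorophenyl compound stands apart from the other two. Nothing available accounts for these differences.

Still open, as far as these compounds go, is whether the ring nitrogen of quinolin-2-yl matters, which naphthalen-2-yl on the same carbonyl carbon would test. Also open, from the compounds shown here alone, is whether an aromatic group is needed at all, which cyclohexyl or a plain butyl chain would show.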